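From a Nitro Group to a Methoxy on the Pendant Ring

A few compounds are considered here, and "the series" means these few. Any claim that something is new, unique, unknown or untested is made for them only; others in the source may bear on it.

Three compounds have been measured in a functional assay on MOLT-4 cells (Homo sapiens) for antiproliferative activity; on this read-out higher numbers stand for weaker inhibition and lower numbers for stronger inhibition:

compound 1, `COc1cc(C(=O)c2sc(-c3cc(OC)c(OC)c(OC)c3)cc2N)cc(OC)c1OC`, gives 1200 nM
compound 2, `COc1cc(C(=O)c2sc(-c3ccc([N+](=O)[O-])cc3)cc2N)cc(OC)c1OC`, gives 110 nM
compound 3, `COc1cc(C(=O)c2sc(-c3ccc(-c4ccccc4)cc3)cc2N)cc(OC)c1OC`, reaches only a limit of the assay, > 10000 nM

Compound 2 has the lowest of the two numbers, and compound 1 stands clearly higher. Compound 3 sits at the limit of > 10000 nM in this assay, at which 1 of the 3 values shown sits.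

Compound 4, `COc1cccc(-c2cc(N)c(C(=O)c3cc(OC)c(OC)c(OC)c3)s2)c1`, differs from compound 2 in one place: 3-methoxyphenyl in place of 4-nitrophenyl on an aromatic carbon. Among the measured compounds shown here, only one measured step touches that same nitro group: an at least 90-fold higher number from compound 2 to compound 3 (1.95 log units; beyond the scatter). That step replaced the nitro with a much larger phenyl and lost potency heavily; a 3-methoxyphenyl is a smaller change, and compound 1, which also carries methoxy groups on the pendant ring, still gives a number rather than a limit. Compound 4 is therefore expected to be a weaker inhibitor than its parent, by a step estimated as a 5.5-fold higher number from compound 2 to compound 4 (0.74 log units; beyond the scatter). For compound 4 the estimate is 600 nM, with a range from 150 nM to 3000 nM.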

Compound 4, half-maximal inhibitory concentration: 17 nM
The estimate for compound 4 lay 35-fold (1.55 log units) above the measured number; measured number below the stated range.
By their numbers in this assay, from the lowest: compound 4; then compound 2; then compound 1. At a limit, above all of these: compound 3.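

In this assay, 3-methoxyphenyl in place of 4-nitrophenyl gives a 6.5-fold lower number from compound 2 to compound 4 (0.81 log units; beyond the scatter). Among the compounds shown here, until now, the only step at this position, the aromatic carbon next to the ring sulfur, had been a loss, so this is the first sign that the pendant ring can be changed with a gain and that the nitro group is not needed for activity. Nothing shown here gives a measured reason for that gain.

Compound 4 changes both the group and its place on the pendant ring, so the effect of the group itself and the effect of its place remain unseparated. Equally open, going by these compounds, is how a pendant ring carrying a fluorine, a hydroxyl or an amine would compare with compound 4.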